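Working notes: amino in place of fluoro, compound 4

This account rests on a few compounds, and the source may have more. Where it says the series, first, only, none or still open, it means among the compounds named here.

Measured in a functional assay on MDA-MB-231 cells (Homo sapiens) for cytotoxicity, read by fluorescence and resazurin assay, with a stated time of 72 h; a lower number here means a stronger inhibitor, a higher number a weaker inhibitor:
- compound 1 `Nc1nc(Nc2ccc(S(N)(=O)=O)cc2)sc1C(=O)c1ccccc1[N+](=O)[O-]`: 1500 nM
- compound 2 `Nc1nc(Nc2ccc(S(N)(=O)=O)cc2)sc1C(=O)c1cccc(F)c1`: 1200 nM
- compound 3 `Nc1nc(Nc2ccc(S(N)(=O)=O)cc2)sc1C(=O)c1ccc(S(N)(=O)=O)cc1`: > 10000 nM, a limit of the assay and not a number

In this assay, among the measured compounds shown here, compound 2 gives 1200 nM, and the only other number stays within the scatter of it: a 1.3-fold lower number from compound 1 to compound 2 (0.10 log units; within the scatter). That measured step puts 3-fluorophenyl in place of 2-nitrophenyl on a carbonyl carbon. Compound 3 has only a limit, so it gives no number for comparison.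

The next structure is compound 4 `Nc1cccc(C(=O)c2sc(Nc3ccc(S(N)(=O)=O)cc3)nc2N)c1`, reached from compound 2 with amino in place of fluoro on an aromatic carbon. For the measured compounds named here, no measured step makes this exact replacement. Going by the values given here, the one step that bears on it changes the same aromatic group and stays within the scatter, so no step beyond the scatter is expected in this assay. The estimated result is a 1.3-fold higher number from compound 2 to compound 4 (0.10 log units; within the scatter). The expected range reaches further upward because the limit of > 10000 nM in this assay, at which 1 of the 3 values shown sits, belongs to compound 3. For compound 4 the estimate is 1500 nM, with an expected range of 500 nM to 5000 nM.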

Compound 4, half-maximal inhibitory concentration: > 10000 nM
Compound 4: no number, only a limit; the forecaster's own chance of this, stated with the estimate: 10%; middle value at least 6.6-fold (0.82 log units) away from the limit.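

In this assay compound 4 gives > 10000 nM, a limit of the assay and not a number, and it is not alone there: the limit of > 10000 nM in this assay, at which 2 of the 4 values shown sit.

Among the compounds shown here, this is the first change on the aryl ketone group to give a step beyond the scatter, an at least 8.3-fold higher number from compound 2 to compound 4 (0.92 log units; beyond the scatter), and the comparison with the nitro analogue gives an at least 6.6-fold higher number from compound 1 to compound 4 (0.82 log units; beyond the scatter), whereas the one earlier step stayed within the scatter. The exchange of a single heavy atom, fluoro to amino, meta to a large group, is therefore enough to move the result out of the measurable range.

The compounds shown leave open whether this loss belongs to the free amino group alone or extends to other groups at this place. An acetamido group, a dimethylamino group or a hydroxyl group on the same carbon would separate these readings.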